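Nitrogen Methylation and Permeability in a Small Series

This account rests on a few compounds, and the source may have more. Where it says the series, first, only, none or still open, it means among the compounds named here.

Of the compounds shown here, three have been measured in an ADME assay for permeability, using PAMPA, at pH 4; on this read-out higher numbers stand for higher permeability and lower numbers for lower permeability. Compound 1 `COc1ccc2[nH]c(C)c(Cc3ccccc3)c(=O)c2c1` gives 167 10^-6 cm/s in this assay. Compound 2 `COc1ccc2c(=O)c(Cc3ccccc3)c(C)[nH]c2c1` has the same atoms as compound 1, joined differently; the difference between the two cores is not broken down here. In this assay compound 2 gives 200 10^-6 cm/s, and this value and that of compound 1 lie within the scatter of each other. Compound 3 `COc1ccc2c(c1)c(=O)c(Cc1ccccc1)c(C)n2C` differs from compound 1 in one place, (methyl in place of hydrogen on an aromatic nitrogen), and in this assay compound 3 gives 295 10^-6 cm/s. That single change made a step of a 1.8-fold higher number from compound 1 to compound 3 (0.25 log units; within the scatter).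

Compound 4 `COc1ccc2c(=O)c(Cc3ccccc3)c(C)n(C)c2c1` has not yet been measured. It differs from compound 2 by methyl in place of hydrogen on an aromatic nitrogen. The place of this change reads the same, word for word, as the place of the change from compound 1 to compound 3, so the same change is now made on the core of compound 2. Among the compounds shown this change occurs two times in all. The expectation for compound 4 rests on compound 2, with 200 10^-6 cm/s, and on the step of a 1.8-fold higher number from compound 1 to compound 3 (0.25 log units; within the scatter) seen on the other core, which stayed within the scatter. From compound 2 to compound 4 a step of a 1.6-fold higher number from compound 2 to compound 4 (0.19 log units; within the scatter) is expected, beside the earlier one. For compound 4 in this assay the estimate is 310 10^-6 cm/s, with the likely range running from 180 10^-6 cm/s to 520 10^-6 cm/s.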

Compound 4, apparent permeability: 432 10^-6 cm/s
Estimate against measurement, compound 4: 1.4-fold (0.14 log units) below, and the stated range covers the measured number.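

On the core of compound 2, methyl in place of hydrogen on an aromatic nitrogen gave a step of a 2.2-fold higher number from compound 2 to compound 4 (0.33 log units; beyond the scatter) in this assay. Set beside the same change on the core of compound 1, the new step does not differ from the earlier one, and so within this series the change carried from one core to the other with the same direction and a size that cannot be told apart: the same change on two cores in this assay, a 1.8-fold higher number (0.25 log units; within the scatter) from compound 1 to compound 3 and a 2.2-fold higher number (0.33 log units; beyond the scatter) from compound 2 to compound 4, 1.2-fold (0.09 log units) apart, within the scatter of two such steps. Among the compounds shown here, this rests on only two cores that have the same atoms joined differently, so it gives no rule for any other core, and the fact that one step lies within the scatter and the other beyond it marks no real difference between them.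

The compounds shown leave open whether the step would hold if the hydrogen on the aromatic nitrogen gave way to something other than methyl, such as ethyl, a longer chain or a chain ending in an amine. They also leave open whether it would survive a change elsewhere on the shared core, such as a carboxylic acid or an amine in place of the benzyl group.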